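Methyl to chloro on the aryl ring of compound 2

The compounds below may be only part of what the source reports. "The series", "measured", "known", "first", "only" and "open" are said of these compounds alone.

Measured so far, in a functional assay on MOLT-4 cells (Homo sapiens) for cytotoxicity, with a stated time of 72 h; a higher number here means a weaker inhibitor, a lower number a stronger inhibitor:
Compound 1, `CN(C)c1ccc(/C=C2\CCC/C(=C\c3ccccc3[N+](=O)[O-])C2=O)cc1`: 122000 nM
Compound 2, `Cc1ccc(/C=C2\CCC/C(=C\c3cccc([N+](=O)[O-])c3)C2=O)cc1`: 9530 nM
Compound 3, `COc1ccc(/C=C2\CCC/C(=C\c3ccccc3[N+](=O)[O-])C2=O)cc1`: 8900 nM

Among these three, compound 2 sits second highest. Its nearest neighbour is compound 3, whose number differs from it by an amount inside the usual scatter, so the two cannot be told apart on this evidence. Compound 1 stands far above both, beyond the scatter. For the measured compounds named here, the one single-point step measured so far is a 14-fold lower number from compound 1 to compound 3 (1.14 log units; beyond the scatter), a change in which methoxy replaces dimethylamino on an aromatic carbon.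

The next compound, compound 4, `O=C1/C(=C/c2ccc(Cl)cc2)CCC/C1=C\c1cccc([N+](=O)[O-])c1`, arises from compound 2 by chloro in place of methyl on an aromatic carbon. Going by the values given here, no measured step swaps methyl for chloro, and the only step in hand alters a different group at a comparable place, so it does not speak directly to this exchange. With nothing pointing either way, compound 4 is expected to land close to compound 2 in this assay, the step of a 1.2-fold lower number from compound 2 to compound 4 (0.08 log units; within the scatter) being estimated to stay within the scatter. The estimate for compound 4 is therefore 8000 nM, with a range from 3000 nM to 25000 nM.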

Compound 4, half-maximal inhibitory concentration: 2020 nM
Compound 4: the middle estimate sits 4.0-fold (0.60 log units) above what was measured; measured number below the stated range.
By their numbers in this assay, from the lowest: compound 4; then compounds 3 and 2 (each within the scatter of the next); then compound 1.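

In this assay the exchange of methyl for chloro on an aromatic carbon para to a large group is not neutral, giving a 4.7-fold lower number from compound 2 to compound 4 (0.67 log units; beyond the scatter) even though one heavy atom replaces one heavy atom and neither group counts a hydrogen-bond donor or acceptor. For the compounds shown here, until now the only single-place step was a 14-fold lower number from compound 1 to compound 3 (1.14 log units; beyond the scatter) in another pair of compounds, and the new step shows that the smaller 4-methylphenyl to 4-chlorophenyl change also moves the number beyond the scatter, though by less. No measurement among the data shown accounts for the difference between chloro and methyl here.

Whether this lower number belongs to chloro alone stays open, since the compounds shown do not include fluoro, bromo, trifluoromethyl or a carboxylic acid on this same carbon. Also open, going by these compounds, is whether chloro would give a step of similar size in a compound with a different second aryl ring, as the exchange is seen in this one pair only.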